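From Compound 3 to an Amino Analogue

The source may hold more compounds than are shown below. What is called first, only, known or untested is meant among the compounds shown, and "the series" means these compounds.

In a functional assay on DU-145 cells (Homo sapiens) for cytotoxicity, read by trypan blue exclusion, with a stated time of 96 h (a lower number here means a stronger inhibitor, a higher number a weaker inhibitor), compound 1 `COc1cc(OC)c(/C=C/S(=O)(=O)Nc2cc(N)c(OC)c(N)c2)c(OC)c1` gives 2500 nM, compound 2 `COc1cc(OC)c(/C=C/S(=O)(=O)Nc2ccc(OC)c(F)c2)c(OC)c1` gives 200 nM, and compound 3 `COc1cc(OC)c(/C=C/S(=O)(=O)Nc2ccc(OC)c(OP(=O)(O)O)c2)c(OC)c1` gives 40 nM, the lowest of the three numbers. Compound 4 `COc1cc(OC)c(/C=C/S(=O)(=O)Nc2ccc(OC)c(N)c2)c(OC)c1` remains unmeasured and differs from compound 3 by one nitrogen atom in place of a group of 5 heavy atoms (4 oxygen, 1 phosphorus; no ring), on an aromatic carbon: one nitrogen atom in place of a group of 5 heavy atoms, on an aromatic carbon. Going by the values given here, the only measured step bearing on this place is a 5.0-fold lower number from compound 2 to compound 3 (0.70 log units; beyond the scatter), which introduced that same group in place of one fluorine atom. Compound 1, which also bears amino, sits high at 2500 nM. A modest step toward a higher number is therefore expected in this assay. The expected change is a 2.5-fold higher number from compound 3 to compound 4 (0.40 log units; beyond the scatter). For compound 4 the estimated value is 100 nM, with an expected range of 25 nM to 400 nM.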

Compound 4, half-maximal inhibitory concentration: 5 nM
For compound 4 the middle estimate is 20-fold (1.30 log units) above the measured one; measured number below the stated range.
By their numbers in this assay, from the lowest: compound 4; then compound 3; then compound 2; then compound 1.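

In this assay, amino on this aromatic carbon, ortho to a methoxy group, gives a lower number than either group seen there earlier, with an 8.0-fold lower number from compound 3 to compound 4 (0.90 log units; beyond the scatter) and a 40-fold lower number from compound 2 to compound 4 (1.60 log units; beyond the scatter). Replacing the other amino group of compound 1 with hydrogen gives a 500-fold lower number from compound 1 to compound 4 (2.70 log units; beyond the scatter), so a single amino group goes with the lowest number of the series, and the high number of compound 1 does not apply to it.

Nothing given explains these steps. On these data alone, whether a hydroxyl group, a methylamino group or an acetamide on the same carbon would match amino remains open.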